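Methoxy for Chloro: Estimating Compound 4 in this assay

The source may report more compounds than this note shows. Statements on the series, on what has been measured and on what is new or still open speak of the compounds shown alone.

Of the compounds shown here, three sharing one core have been measured in a functional assay on PC-3 cells (Homo sapiens) for antiproliferative activity, read by MTT assay; on this read-out lower numbers stand for stronger inhibition and higher numbers for weaker inhibition. Compound 1 `CNC(=O)c1ccc(Oc2cccc(NC(=S)Nc3ccc(Cl)cc3)c2)nc1` gives 28400 nM. Compound 2 `CNC(=O)c1ccc(Oc2cccc(NC(=S)Nc3ccc(C)c(C)c3)c2)nc1` gives 67400 nM, and compound 3 `CNC(=O)c1ccc(Oc2cccc(NC(=S)Nc3ccc(Br)c(C(F)(F)F)c3)c2)nc1` gives 2670 nM. Compound 1 thus stands second highest of the three: compound 2 is its nearest neighbour and lies somewhat higher, while compound 3 is furthest away and far lower. Compound 4 `CNC(=O)c1ccc(Oc2cccc(NC(=S)Nc3ccc(OC)cc3)c2)nc1` is not yet measured. It differs from compound 1 in one place: methoxy in place of chloro on an aromatic carbon. Within the data shown here, only one measured step changes a group on that same ring, and it reads a 2.4-fold higher number from compound 1 to compound 2 (0.38 log units; beyond the scatter); there, too, a halogen-free substituent replaced the chloro group, and the number rose modestly. On that basis a small rise beyond the scatter, or no clear change, is expected here; the step from compound 1 to compound 4 is estimated as a 1.8-fold higher number from compound 1 to compound 4 (0.25 log units; within the scatter). Compound 4 is therefore expected to give about 50000 nM in this assay, within a range from 15000 nM to 150000 nM.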

Compound 4, half-maximal inhibitory concentration: > 100000 nM
Compound 4 ended at the assay's limit; the forecaster's own chance of this, stated with the estimate: 10%; middle value at least 2.0-fold (0.30 log units) from the limit.
By their numbers in this assay, from the lowest: compound 3; then compound 1; then compound 2. At a limit, above all of these: compound 4.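

In this assay compound 4 gives > 100000 nM, which is a limit and not a number, and it is the only such result among these compounds: the limit of > 100000 nM in this assay, at which 1 of the 4 values shown sits.

Among these compounds, for the first time, a single swap of one group on this ring, with nothing else altered, can be read alone: an at least 3.5-fold higher number from compound 1 to compound 4 (0.54 log units; beyond the scatter), and since this is only a floor, the true step may be larger. The earlier step on this ring replaced 4-chlorophenyl with 3,4-dimethylphenyl, whereas this one shows that methoxy in place of chloro is enough for a clear loss, while the comparison with the other weak compound reads an at least 1.4-fold higher number from compound 2 to compound 4 (0.17 log units; that floor lies within the scatter), so no order between those two can be claimed.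

Going by these compounds, the true number of compound 4 stays unknown, so how far the loss goes remains open. The compounds shown also leave open how a hydroxy group, an amine or a longer chain such as ethoxy would read at this same place on the ring.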